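The source may report more compounds than this note shows. Statements on the series, on what has been measured and on what is new or still open speak of the compounds shown alone.

Among the measured compounds shown here, in a functional assay on HOS cells (Homo sapiens) for inhibition, with a stated time of 72 h (a higher number here means a weaker inhibitor, a lower number a stronger inhibitor), compound 1 `NC1CCC(Nc2nc(NCc3ccc(-c4ccco4)cc3)c3ncn(C4CCCC4)c3n2)CC1` gives 102 nM as the lower of the two numbers so far, and compound 2 `NC1CCC(Nc2nc(NCc3ccc(-c4ccccc4O)cc3)c3ncn(C4CCCC4)c3n2)CC1` gives 1160 nM as the higher. For the measured compounds named here, the one measured step (an 11-fold higher number from compound 1 to compound 2 (1.06 log units; beyond the scatter)) puts 2-hydroxyphenyl in place of furan-2-yl on an aromatic carbon and is large. Compound 3 `Nc1ccccc1CNc1nc(NC2CCC(N)CC2)nc2c1ncn2C1CCCC1` is still unmeasured. It carries 2-aminophenyl in place of 4-(furan-2-yl)phenyl on a saturated chain carbon bound to a nitrogen on an aromatic ring. This is a different change, so compound 2 offers only indirect guidance, yet it also loses the furan-2-yl and its step (an 11-fold higher number from compound 1 to compound 2 (1.06 log units; beyond the scatter)) points to a weaker inhibitor. A similarly large rise is therefore expected in this assay, and the estimated step is a 15-fold higher number from compound 1 to compound 3 (1.17 log units; beyond the scatter) with wide uncertainty. Compound 3 is expected to give about 1500 nM (estimated range 400 nM to 6000 nM).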

Compound 3, half-maximal inhibitory concentration: 2030 nM
The estimate for compound 3 lay 1.4-fold (0.13 log units) below the measured number, within the range that was stated.
By their numbers in this assay, from the lowest: compound 1; then compounds 2 and 3 (each within the scatter of the next).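

In this assay, swapping the whole 4-(furan-2-yl)phenyl for the smaller 2-aminophenyl on the saturated chain carbon bound to a nitrogen on an aromatic ring gives a 20-fold higher number from compound 1 to compound 3 (1.30 log units; beyond the scatter) and is a large step. Compound 1 therefore keeps the lowest number of the three, and a second, quite different replacement does not bring that number back. Compound 2 and compound 3 lie within the scatter of each other, so here the number does not separate a replacement that keeps an outer ring from one that has none, and no measurement available explains the rise.

This change removes the furan-2-yl ring, shortens the group and adds an amine all at once, so the compounds shown cannot say which of these matters. Going by these compounds, a plain phenyl at this place would help separate them, and whether a 4-(thiophen-2-yl)phenyl group would keep the low number of compound 1 also remains open.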